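This account rests on a few compounds, and the source may have more. Where it says the series, first, only, none or still open, it means among the compounds named here.

Measured so far:
Compound 1 `CNCc1cc(-c2ccccc2C)n(S(=O)(=O)c2ccc(C)cc2)c1`: 2.12
Compound 2 `CNCc1cc(-c2ccccc2F)n(S(=O)(=O)c2ccc(C)cc2)c1`: 1.56

In a physicochemical assay for lipophilicity, read by HPLC, at pH 7.4 (on this read-out lower numbers stand for lower lipophilicity and higher numbers for higher lipophilicity), compound 2 has the lower of the two numbers, at 1.56. The next structure, compound 3 `CNCc1cc(-c2ccc(F)cc2)n(S(=O)(=O)c2ccc(C)cc2)c1`, has the same atoms joined differently, with 4-fluorophenyl in place of 2-fluorophenyl on an aromatic carbon. For the measured compounds named here, only one measured step exists, a number 0.56 log units lower from compound 1 to compound 2 (beyond the scatter), a modest change beyond the scatter. That step swaps fluoro for methyl and does not shift the fluorine, so it offers only a loose guide to size. A smaller move is expected here, with the estimate being a number 0.09 log units higher from compound 2 to compound 3 (within the scatter), possibly no more than scatter. For compound 3 the estimated value is 1.65, within an expected range of 1.3 to 2.05.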

Compound 3, distribution coefficient: 2.05
Beside the measured number, compound 3's estimate is 0.40 log units below it, and the stated range covers the measured number.
By their numbers in this assay, from the lowest: compound 2; then compounds 3 and 1 (each within the scatter of the next).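

In this assay, 4-fluorophenyl in place of 2-fluorophenyl gives a number 0.49 log units higher from compound 2 to compound 3 (beyond the scatter), so on this aromatic carbon the place of the fluorine on the phenyl ring counts, not only its presence. 4-fluorophenyl in place of 2-methylphenyl gives a number 0.07 log units lower from compound 1 to compound 3 (within the scatter), a step within the scatter. Nothing at hand accounts for the effect of moving the fluorine. Still open, from the compounds shown here alone, is how a chloro or methoxy group on this phenyl ring would read. A carboxylic acid there also remains untested among the compounds shown.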